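Methoxy for Nitro: Expected Binding of Compound 4

The source may hold more compounds than are shown below. What is called first, only, known or untested is meant among the compounds shown, and "the series" means these compounds.

Compound 1 `CCOc1cccc2cc(-c3ccc(OC)cc3)c(=O)oc12`: 5320 nM
Compound 2 `Cc1cccc2cc(-c3ccc([N+](=O)[O-])cc3)c(=O)oc12`: > 100000 nM
Compound 3 `COc1cccc2cc(-c3ccc([N+](=O)[O-])cc3)c(=O)oc12`: 8020 nM

In an assay on CHO cells for displacement of a labelled ligand from adenosine receptor A3 (Homo sapiens), read by radioligand binding (on this read-out higher numbers stand for weaker inhibition and lower numbers for stronger inhibition), compound 3 gives 8020 nM, the highest of the two numbers shown. Compound 1 gives 5320 nM, within the scatter of compound 3. For compound 2 the assay reports only a limit, > 100000 nM (the limit of > 100000 nM in this assay, at which 1 of the 3 values shown sits). Within the data shown here, the one measured step, an at least 12-fold lower number from compound 2 to compound 3 (1.09 log units; beyond the scatter), concerns the core and not the pendant ring, so it does not bear on the present change. Compound 4 `COc1ccc(-c2cc3cccc(OC)c3oc2=O)cc1` differs from compound 3 by methoxy in place of nitro on an aromatic carbon. Compound 1 already carries methoxy on that ring and sits close to compound 3, so the step of a 1.5-fold lower number from compound 3 to compound 4 (0.16 log units; within the scatter) is expected to stay within the scatter. Compound 4 is therefore estimated at 5500 nM, between 1800 nM and 17000 nM.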

Compound 4, inhibition constant: 5060 nM
For compound 4 the middle estimate is 1.1-fold (0.04 log units) above the measured one; low and high end bracket the measured number.
By their numbers in this assay, from the lowest: compounds 4, 1 and 3 (each within the scatter of the next). At a limit, above all of these: compound 2.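

In this assay, methoxy in place of nitro on an aromatic carbon, para to a large group, gives a 1.6-fold lower number from compound 3 to compound 4 (0.20 log units; within the scatter), so the number at this position stays within the scatter across this exchange. Hydrogen in place of methyl at the end of the chain on the oxygen gives a 1.1-fold lower number from compound 1 to compound 4 (0.02 log units; within the scatter), which is also within the scatter. Nothing shown here gives a reason for either result. The compounds shown leave open whether an amine or a carboxylic acid on that aromatic carbon would also stay within the scatter. They also leave open what a longer chain on the oxygen would do.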